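This account rests on a few compounds, and the source may have more. Where it says the series, first, only, none or still open, it means among the compounds named here.

Measured so far:
compound 1 `CCNC(=O)c1cc(Oc2ccc(NC(=O)c3cc4cccnc4n(-c4ccc(OC)cc4)c3=O)cc2)ccn1` gives 2010 nM
compound 2 `CCCNC(=O)c1cc(Oc2ccc(NC(=O)c3cc4cccnc4n(-c4ccccc4F)c3=O)cc2)ccn1` gives 150 nM
compound 3 `CCCNC(=O)c1cc(Oc2ccc(NC(=O)c3cc4cccnc4n(-c4ccc(Br)cc4)c3=O)cc2)ccn1` gives 150 nM

In a functional assay on A549 cells (Homo sapiens) for antiproliferative activity, read by MTT assay, with a stated time of 72 h (on this read-out lower numbers stand for stronger inhibition and higher numbers for weaker inhibition), compound 3 stands level with compound 2, the two together being the lowest of the three numbers, while compound 1 sits well beyond the scatter above them. Compound 4 `CCCNC(=O)c1cc(Oc2ccc(NC(=O)c3cc4cccnc4n(-c4ccc(OC)cc4)c3=O)cc2)ccn1` differs from compound 3 by methoxy in place of bromo on an aromatic carbon. For the measured compounds named here, the one measured step on that aromatic ring, no change at the digits printed from compound 2 to compound 3 (within the scatter), left the number unchanged. Going by the values given here, compound 1, the only measured compound carrying the methoxy group, gives 2010 nM, but it also differs from compound 4 elsewhere, so that gap cannot be laid on the methoxy group alone. Compound 4 is therefore expected to show a modest rise, a 3.0-fold higher number from compound 3 to compound 4 (0.48 log units; beyond the scatter), with a wide range. The estimate for compound 4 is 450 nM, between 130 nM and 2000 nM.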

Compound 4, half-maximal inhibitory concentration: 820 nM
Beside the measured number, compound 4's estimate is 1.8-fold (0.26 log units) below it; the range from low to high includes it.
By their numbers in this assay, from the lowest: compounds 2 and 3 (each within the scatter of the next); then compound 4; then compound 1.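

In this assay, the place on the phenyl ring that gave no change between the earlier 2-fluorophenyl and 4-bromophenyl compounds proves sensitive to the group it carries: methoxy in place of bromo gives a 5.5-fold higher number from compound 3 to compound 4 (0.74 log units; beyond the scatter), and the 2-fluorophenyl comparison gives a 5.5-fold higher number from compound 2 to compound 4 (0.74 log units; beyond the scatter). The added methyl on the amide chain also counts with methoxy present, giving a 2.5-fold lower number from compound 1 to compound 4 (0.39 log units; beyond the scatter). Nothing shown explains either step. Still open, on these data alone, is whether hydroxy or an amine at this place would behave like methoxy or like bromo. Also open, as far as these compounds go, is whether a longer chain on the amide would lower the number further.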